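A few compounds are considered here, and "the series" means these few. Any claim that something is new, unique, unknown or untested is made for them only; others in the source may bear on it.

Measured compounds:
compound 1 `COc1ccc(F)cc1CNCCCNc1ccnc2cc(Cc3ccc(C#N)cc3)ccc12`: 23 10^-6 cm/s
compound 2 `c1ccc(CCc2ccc3c(NCCCNCc4ccco4)ccnc3c2)cc1`: 23 10^-6 cm/s

In an ADME assay for permeability, using PAMPA, with a stated time of 30 min, at pH 7.4 (a lower number here means that the compound crosses the layer more slowly, a higher number that the compound crosses the layer faster), compound 1 gives 23 10^-6 cm/s, and compound 2 gives 23 10^-6 cm/s; the two values are level at the digits shown, so nothing separates them beyond the usual scatter, and the two values are all that is known of that pair. Among the compounds with values here, both compounds thus sit at the same point on the permeability scale, with no measured step between them.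

Compound 3 `COc1ccc(F)cc1CNCCCNc1ccnc2cc(-c3ccc(F)cc3)ccc12` is not yet measured in this assay. It differs from compound 1 in one place:

4-fluorophenyl in place of 4-cyanobenzyl on an aromatic carbon

Within the data shown here, no step between measured compounds bears on this change, so the expectation rests on compound 1 alone. Compound 3 is expected to come out near its parent, with the step of a 1.1-fold higher number from compound 1 to compound 3 (0.04 log units; within the scatter) estimated as small and not beyond the scatter. The estimate for compound 3 is 25 10^-6 cm/s, expected between 12 10^-6 cm/s and 50 10^-6 cm/s.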

Compound 3, apparent permeability: 237 10^-6 cm/s
Compound 3: middle estimate off by 9.5-fold (0.98 log units), on the low side; measured number above the stated range.
By their numbers in this assay, from the lowest: compounds 1 and 2 (each within the scatter of the next); then compound 3.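

In this assay, within the data shown here, this aromatic carbon of the core proves far from silent: 4-fluorophenyl in place of 4-cyanobenzyl gives a 10-fold higher number from compound 1 to compound 3 (1.01 log units; beyond the scatter) and is the first step, since compound 1 and compound 2 only sit level and differ in more than one place. A single change at this position, with the rest of compound 1 held fixed, is therefore enough to move the read-out by a large step. Nothing available bears on the origin of this step.

The change swaps the nitrile for fluorine and also removes the carbon joining the benzyl ring to the core, and the compounds shown do not separate these two differences. Going by these compounds, whether 4-fluorobenzyl, 4-cyanophenyl or a phenyl ring carrying a carboxylic acid or an amine would follow compound 3 at this position remains open.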